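Swapping 2-Methoxyphenyl for 4-Methoxyphenyl

The source may hold more compounds than are shown below. What is called first, only, known or untested is meant among the compounds shown, and "the series" means these compounds.

In a functional assay on COLO 205 cells (Homo sapiens) for cytotoxicity, read by sulforhodamine B assay, with a stated time of 48 h (a higher number here means a weaker inhibitor, a lower number a stronger inhibitor), compound 1 `COc1cc(/C=C/C(=O)/C=C/c2cccc3ccccc23)ccc1OCc1cn(CCOc2cc(=O)oc3ccccc23)nn1` gives 9950 nM and compound 2 `COc1ccccc1/C=C/C(=O)/C=C/c1ccc(OCc2cn(CCOc3cc(=O)oc4ccccc34)nn2)c(OC)c1` gives 11500 nM. Within the data shown here, these are the only two numbers so far, and compound 2 stands level with compound 1 within the usual scatter of repeated measurements. Compound 3 `COc1ccc(/C=C/C(=O)/C=C/c2ccc(OCc3cn(CCOc4cc(=O)oc5ccccc45)nn3)c(OC)c2)cc1` has the same atoms as compound 2, joined differently: 4-methoxyphenyl in place of 2-methoxyphenyl on a double-bonded chain carbon bound to a double-bonded chain carbon. Among the measured compounds shown here, the one measured step bearing on this replaced a whole group at that same place, naphthalen-1-yl by 2-methoxyphenyl, and gave a 1.2-fold higher number from compound 1 to compound 2 (0.06 log units; within the scatter). For the measured compounds named here, it is thin evidence, and no measured step tests the methoxy position itself. The expected change is therefore no larger than the scatter, an estimated 1.0-fold lower number from compound 2 to compound 3 (0.02 log units; within the scatter). For compound 3 the estimated value is 11000 nM, with an expected range of 5500 nM to 22000 nM.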

Compound 3, half-maximal inhibitory concentration: 11300 nM
Compound 3: the middle estimate sits 1.0-fold (0.01 log units) below what was measured; the range from low to high includes it.
By their numbers in this assay, from the lowest: compounds 1, 3 and 2 (each within the scatter of the next).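

Moving the methoxy group from 2-methoxyphenyl to 4-methoxyphenyl tests its position on this ring directly for the first time, and in this assay this gives a 1.0-fold lower number from compound 2 to compound 3 (0.01 log units; within the scatter), which is within the scatter. Replacing the naphthalen-1-yl group with 4-methoxyphenyl gives a 1.1-fold higher number from compound 1 to compound 3 (0.06 log units; within the scatter), also within the scatter, so all three groups at this place on a double-bonded chain carbon read alike in this assay. Nothing measured here offers an explanation for these level numbers.

The compounds shown leave open whether a phenyl ring carrying an amine or a carboxylic acid at this place would give a number beyond the scatter. They also leave open whether a longer chain elsewhere on the shared core would do so.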